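Swapping the Aryl Group on the Piperazine Ring

The source may report more compounds than this note shows. Statements on the series, on what has been measured and on what is new or still open speak of the compounds shown alone.

Compound 1, `COc1ccccc1N1CCN(Cc2ccc(CN3C(=O)c4ccccc4S3(=O)=O)cc2)CC1`: 10100 nM
Compound 2, `COc1ccccc1N1CCN(CCCCCN2C(=O)c3ccccc3S2(=O)=O)CC1`: 1990 nM

Both compounds were tested in an assay on HEK293 cells for displacement of a labelled ligand from 5-hydroxytryptamine receptor 6 (Homo sapiens); a higher number here means a weaker inhibitor, a lower number a stronger inhibitor. Compound 1, which carries the two ring systems on a benzene-containing linker, gives 10100 nM in this assay. Compound 2, with a five-carbon chain in its place, gives 1990 nM. Compound 2 therefore has the lower of the two numbers, and its gap to compound 1 is beyond the usual scatter of repeated measurements, so compound 2 counts as the stronger inhibitor of the pair.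

Compound 3, `O=C1c2ccccc2S(=O)(=O)N1CCCCCN1CCN(c2cccc(Cl)c2Cl)CC1`, keeps the five-carbon chain and the shared core of compound 2 and changes only the aryl group on the piperazine: 2,3-dichlorophenyl in place of 2-methoxyphenyl on an amine nitrogen in a ring. Going by the values given here, no measured pair shows what this particular swap does in this assay, so the expectation rests on the fact that the rest of compound 3 matches compound 2. Compound 3 is expected to give roughly 2500 nM, within a range from 700 nM to 9000 nM. That estimate means a 1.3-fold higher number from compound 2 to compound 3 (0.10 log units; within the scatter), a change expected to stay within the scatter rather than a step in either direction.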

Compound 3, inhibition constant: 197 nM
Compound 3: middle estimate off by 13-fold (1.10 log units), on the high side, and the stated range ends above it.
By their numbers in this assay, from the lowest: compound 3; then compound 2; then compound 1.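

The aryl group on the piperazine matters in this assay, since changing it alone, with the chain and the shared core held constant, gives a 10-fold lower number from compound 2 to compound 3 (1.00 log units; beyond the scatter) as 2,3-dichlorophenyl replaces 2-methoxyphenyl. This is the first step shown that isolates this position on the amine nitrogen in the ring, and it makes that position a clear point of sensitivity in this short series. The two groups match in heavy-atom count and differ in their atoms and hydrogen-bond acceptors, but no measurement shown explains why the number falls.

This single swap removes a methoxy group and adds two chlorine atoms at once, so the compounds shown leave open which part of the change accounts for the step; a plain phenyl group or a phenyl ring with a single chlorine on the same chain and shared core could help separate them. Going by these compounds, it also remains open whether 2,3-dichlorophenyl would bring a similar step on the benzene-containing linker of compound 1 or on a longer chain.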